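The compounds below may be only part of what the source reports. "The series", "measured", "known", "first", "only" and "open" are said of these compounds alone.

Compound 1, `Cc1ccsc1C(=CCCN(C)C(CCO)C(=O)NCc1ccccc1)c1sccc1C`, is the starting point. In a physicochemical assay for lipophilicity, read by HPLC (on this read-out lower numbers stand for lower lipophilicity and higher numbers for higher lipophilicity), compound 1 gives 5.71, the lowest of the two single numbers at hand, though its nearest neighbour, compound 3, `Cc1ccsc1C(=CCCN(C)C(CCN)C(=O)NCc1ccc(Cl)cc1)c1sccc1C`, gives 5.85 in this assay, a gap that falls within the scatter. Compound 2, `Cc1ccsc1C(=CCCN(C)C(CC(C)O)C(=O)NCc1ccccc1Cl)c1sccc1C`, has been measured more than once in this assay, where compound 2 gives 5.95; 5.67 (2 entries), and its entries the several entries of compound 2 in this assay, 5.95; 5.67 (2 entries) show how far repeated readings of one compound can spread.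

Compound 4, `Cc1ccsc1C(=CCCN(C)C(CCO)C(=O)NCc1ccc(F)cc1)c1sccc1C`, has not yet been measured in this assay. It differs from compound 1 in one place: fluoro in place of hydrogen on an aromatic carbon.

Among the measured compounds shown here, no single-change step between two measured compounds is available to set the size of this exchange. Across the three measured compounds the numbers sit close together, so compound 4 is expected to land near compound 1, with a step of a number 0.14 log units higher from compound 1 to compound 4 (within the scatter) that is not expected to exceed the scatter. Compound 4 is therefore estimated at 5.85, between 5.55 and 6.15 in this assay.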

Compound 4, partition coefficient: 5.87
Compound 4: the middle estimate sits 0.02 log units below what was measured, within the range that was stated.
By their numbers in this assay, from the lowest: compounds 1, 3 and 4 (each within the scatter of the next).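

Among the compounds shown here, this is the first single-change step at this place: in this assay, fluoro in place of hydrogen on an aromatic carbon gives a number 0.16 log units higher from compound 1 to compound 4 (within the scatter). For the compounds shown here, at this position, para to a large group, the exchange therefore produces no difference that can be told from the scatter, something the earlier compounds, which differ from one another in more than one place, could not show. The step is also smaller than the spread of repeated readings of a single compound: the several entries of compound 2 in this assay, 5.95; 5.67 (2 entries)

From the compounds shown here alone, whether trifluoromethyl or methoxy at the same place would give a step beyond the scatter remains open. Also open, going by these compounds, is whether fluoro would give a step of similar size with a carboxylic acid in place of the hydroxyl of compound 1.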